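Five-membered aryl swaps on the shared core

A few compounds are considered here, and "the series" means these few. Any claim that something is new, unique, unknown or untested is made for them only; others in the source may bear on it.

Measured so far in a functional assay on HCT-116 cells (Homo sapiens) for cytotoxicity; on this read-out higher numbers stand for weaker inhibition and lower numbers for stronger inhibition:
compound 1 `COc1ccc(C2=C(c3ccccc3)C(=O)N3CCCC3C2)cc1`: 390 nM
compound 2 `COc1ccc(C2=C(c3ccsc3)C(=O)N3CCCC3C2)cc1`: 1500 nM

Among the compounds with values here, compound 2 gives the higher of the two numbers; the one other measured member, compound 1, sits at a lower number, the step being a 3.8-fold higher number from compound 1 to compound 2 (0.59 log units; beyond the scatter), which is beyond the scatter and of modest size. Within the data shown here, that is the only step available, and it concerns the same position as the next change.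

Compound 3 `COc1ccc(C2=C(c3ccco3)C(=O)N3CCCC3C2)cc1` is not yet measured. It differs from compound 2 by furan-2-yl in place of thiophen-3-yl on a double-bonded ring carbon.

Among the measured compounds shown here, no step exchanges one five-membered heteroaryl for another here. The single bearing observation is that replacing phenyl by thiophen-3-yl at this position raised the number, as shown by a 3.8-fold higher number from compound 1 to compound 2 (0.59 log units; beyond the scatter) from compound 1 to compound 2. Furan-2-yl is again a five-membered aromatic ring with one hetero atom, so the number for compound 3 is expected to stay near that of compound 2, with any step likely within the scatter or small, and no firm direction.

Compound 3 is estimated at 1800 nM in this assay, range 600 nM to 6000 nM, corresponding to an expected step of a 1.2-fold higher number from compound 2 to compound 3 (0.08 log units; within the scatter).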

Compound 3, half-maximal inhibitory concentration: 6000 nM
For compound 3 the middle estimate is 3.3-fold (0.52 log units) below the measured one; the measured number falls inside the stated range.
By their numbers in this assay, from the lowest: compound 1; then compound 2; then compound 3.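

In this assay, the two five-membered rings are not interchangeable on this double-bonded ring carbon: furan-2-yl in place of thiophen-3-yl gives a 4.0-fold higher number from compound 2 to compound 3 (0.60 log units; beyond the scatter) even though the two groups match in heavy-atom count, hetero-atom count and net charge. Measured against phenyl, the same position shows a 15-fold higher number from compound 1 to compound 3 (1.19 log units; beyond the scatter) for furan-2-yl, so the numbers across the three compounds rise from phenyl through thiophen-3-yl to furan-2-yl, with every step beyond the scatter and no compound shown going against that order. No measurement at hand accounts for this order or for the size of its steps.

From the compounds shown here alone, the change from thiophen-3-yl to furan-2-yl alters both the hetero atom and the ring atom of attachment, so it remains open which of the two carries the step; thiophen-2-yl or furan-3-yl on this carbon would separate them. Also open, going by these compounds, is where a six-membered pyridinyl ring, or a five-membered thiazolyl ring with its two hetero atoms, would fall relative to phenyl on the shared core.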